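5-ethylpyridin-3-yl in place of 3-ethylphenyl

This account rests on a few compounds, and the source may have more. Where it says the series, first, only, none or still open, it means among the compounds named here.

Compound 1 `CCc1cccc(CNC(=O)c2nc3cccc(COCc4ccc(C(=O)O)cc4)c3c(=O)[nH]2)c1`: > 40000 nM
Compound 2 `CCc1cccc(CNC(=O)c2nc3ccc(OC)c(COCc4ccc(C(=O)O)cc4)c3c(=O)[nH]2)c1`: > 20000 nM
Compound 3 `CCc1cccc(CNC(=O)c2nc3c(F)ccc(COCc4ccc(C(=O)O)cc4)c3c(=O)[nH]2)c1`: > 20000 nM

In an ADME assay on HEK293 cells (Homo sapiens) for cytotoxicity, read by resazurin assay, with a stated time of 72 h (on this read-out higher numbers stand for lower toxicity in this test and lower numbers for higher toxicity in this test), compound 1 gives > 40000 nM, which is a limit of the assay and not a number. Compound 2 gives > 20000 nM, also a limit. Compound 3 gives > 20000 nM, again a limit. Compound 4 `CCc1cncc(CNC(=O)c2nc3cccc(COCc4ccc(C(=O)O)cc4)c3c(=O)[nH]2)c1` differs from compound 1 in one place: 5-ethylpyridin-3-yl in place of 3-ethylphenyl on a saturated chain carbon bound to an amide-type nitrogen. The nearest measured changes are a step that the two limits leave unreadable from compound 1 to compound 2 and a step that the two limits leave unreadable from compound 1 to compound 3. Both alter the shared core rather than this group, and neither has a readable size. No step beyond the scatter is therefore expected, and no direction is favoured. The expected step is a number no higher from compound 1 to compound 4 (the limit leaves the size open). For compound 4 the estimated value is 40000 nM, with an expected range from 20000 nM to 80000 nM.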

Compound 4, half-maximal cytotoxic concentration in the HEK293 assay: > 20000 nM
Compound 4 gave a limit, no number; the forecaster's own chance of this, stated with the estimate: 80%; the middle value lies beyond the limit too.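

Compound 1 and compound 4 give no readable step, as a limit of the assay, not a number, stands in the way in both the HEK293 assay and a physicochemical assay for solubility, read by nephelometry, in phosphate buffer, measured as kinetic solubility, at pH 6.5; a higher number here means a more soluble compound, a lower number a less soluble compound. In the physicochemical assay compound 1 gives < 1.6 ug/mL, which is a limit of the assay and not a number. In the physicochemical assay compound 4 gives 1.6 ug/mL. From the compounds shown here alone, whether 5-ethylpyridin-3-yl in place of 3-ethylphenyl changes either read-out, and by how much, stays open.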